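Glycidyl ether chalcones: thiophene isomer at the para ether

The source may hold more compounds than are shown below. What is called first, only, known or untested is meant among the compounds shown, and "the series" means these compounds.

Three measured compounds share a chalcone-like core carrying a glycidyl ether. Compound 1 `O=C(/C=C/c1ccco1)c1ccccc1OCC1CO1` gives 36.8% in an assay for inhibition of DNA topoisomerase 1 (Homo sapiens), with a stated time of 30 min, tested at 100 uM; a higher number here means a stronger effect of the compound at the concentration tested, a lower number a weaker effect. Compound 2 `O=C(/C=C/c1cccs1)c1cccc(OCC2CO2)c1` gives 2.7% in this assay, and compound 3 `O=C(/C=C/c1cccs1)c1ccc(OCC2CO2)cc1` gives 0% in this assay. Compound 3 therefore sits at the bottom of the three numbers; compound 2 lies within the scatter of it, while compound 1 stands beyond the scatter above it.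

The next step goes from compound 3 to compound 4 `O=C(/C=C/c1ccsc1)c1ccc(OCC2CO2)cc1`; the change is thiophen-3-yl in place of thiophen-2-yl on a double-bonded chain carbon bound to a double-bonded chain carbon. Going by the values given here, no measured pair shows this change, so its size is unknown from the data. Both measured thiophen-2-yl compounds give numbers close to zero, and nothing here indicates that moving the sulfur within the five-membered ring would change that.

Compound 4 is expected to give 3% in this assay, with a range of 0% to 15%. The estimated step of a number 3 percentage points higher from compound 3 to compound 4 (within the scatter) is thus expected to stay within the scatter.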

Compound 4, a percentage reported as inhibition, at one concentration (the size of the read-out at that concentration, not a potency): 46.3%
Beside the measured number, compound 4's estimate is 43.3 percentage points below it; the whole stated range lies below it.
By their numbers in this assay, from the lowest: compounds 3 and 2 (each within the scatter of the next); then compounds 1 and 4 (each within the scatter of the next).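

Going by these compounds alone, the change to thiophen-3-yl in place of thiophen-2-yl on a double-bonded chain carbon bound to a double-bonded chain carbon gives the first single-place comparison: in this assay it produces a number 46.3 percentage points higher from compound 3 to compound 4 (beyond the scatter). The two groups have the same atoms and the same counted features, so how this ring is joined to the chain is enough to separate a near-zero read-out from a clear one at the concentration tested. Nothing available here bears on the cause of so large a step.

On these data alone, whether thiophen-3-yl has the same effect with the glycidyl ether placed as in compound 1 or compound 2 remains open. Also open, as far as these compounds go, is how this series would read with a phenyl ring on the chain, or with a simple methyl ether in place of the glycidyl ether.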